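This account rests on a few compounds, and the source may have more. Where it says the series, first, only, none or still open, it means among the compounds named here.

Measured compounds in an assay on isolated protein for inhibition of kallikrein-7 (Homo sapiens), read by fluorescence, with stated times of 10 min and 30 min; on this read-out higher numbers stand for weaker inhibition and lower numbers for stronger inhibition:
- compound 1, `COc1ccc(Cl)cc1C[C@@H]1CN/C(=N\N(C)C)CN(CC(=O)Nc2cccc(C(=O)N(C)C)c2)C1=O`, gives 2500 nM
- compound 2, `COc1ccc(Cl)cc1C[C@@H]1CN/C(=N\N(C)C)CN(CC(=O)Nc2cccc(S(=O)(=O)N(C)C)c2)C1=O`, gives 990 nM

Of these two numbers, compound 2 holds the lower one. Among the measured compounds shown here, the only measured step among them, a 2.5-fold lower number from compound 1 to compound 2 (0.40 log units; beyond the scatter), is a modest change in this assay, and it separates compound 2 from its one neighbour by more than the usual scatter.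

Compound 3, `COc1ccc(Cl)cc1C[C@@H]1CN/C(=N\N(C)C)CN(CC(=O)Nc2cccc(S(=O)(=O)C(F)(F)F)c2)C1=O`, is the next member of the series. It differs from compound 2 by trifluoromethyl in place of dimethylamino on a sulfonyl sulfur, so the exchange sits on the sulfonyl sulfur rather than on the aromatic carbon that the earlier step concerned. For the measured compounds named here, no measured step exchanges a substituent on that sulfur; the one step available, from compound 1 to compound 2, replaced the group attached to the ring and is at best a loose guide. On that basis no step beyond the scatter is expected in this assay for compound 3, with a wide range to reflect the lack of a direct precedent. The expected step of a 1.0-fold higher number from compound 2 to compound 3 (0.00 log units; within the scatter) is therefore near zero, and compound 3 is estimated at 1000 nM, between 350 nM and 3000 nM.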

Compound 3, half-maximal inhibitory concentration: 3900 nM
For compound 3 the middle estimate is 3.9-fold (0.59 log units) below the measured one; measured number above the stated range.
By their numbers in this assay, from the lowest: compound 2; then compounds 1 and 3 (each within the scatter of the next).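

In this assay the exchange on the sulfonyl sulfur gives a 3.9-fold higher number from compound 2 to compound 3 (0.60 log units; beyond the scatter), which shows that the group carried by that sulfur matters in its own right, with a step slightly larger in size than the earlier one on the aromatic carbon. The sulfonyl unit on the aromatic carbon therefore does not bring a lower number by itself: (trifluoromethyl)sulfonyl in place of dimethylcarbamoyl gives a 1.6-fold higher number from compound 1 to compound 3 (0.19 log units; within the scatter), so what compound 2 gained over compound 1 is not retained once dimethylamino is replaced. Nothing available explains why these two groups on the sulfur read so differently.

The compounds shown leave open how other groups on that sulfonyl sulfur would read, such as methyl, a plain amino group or a morpholine, and whether the lower number of compound 2 depends on the methyl groups of dimethylamino or would survive a longer chain on that nitrogen. They also leave open whether the same order of these groups would hold on a changed core, since all three compounds share one.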